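Moving Fluorine on the Phenylcarbamoyl Group

A few compounds are considered here, and "the series" means these few. Any claim that something is new, unique, unknown or untested is made for them only; others in the source may bear on it.

Measured compounds:
compound 1 `CN(C)C(=O)c1cc2cnc(Nc3ccc(NC(=O)C4(C(=O)Nc5ccccc5)CC4)cc3)nc2n1C1CCCC1`: 88.8%
compound 2 `CN(C)C(=O)c1cc2cnc(Nc3ccc(NC(=O)C4(C(=O)Nc5ccccc5F)CC4)cc3)nc2n1C1CCCC1`: 88.6%

In a functional assay on A549 cells (Homo sapiens) for inhibition, read by CCK-8 assay, with a stated time of 72 h, tested at 10 uM (a lower number here means less inhibition of growth, a higher number more inhibition of growth at the concentration tested), compound 1 gives 88.8%. Compound 2, its 2-fluorophenyl counterpart, gives 88.6% in this assay. Going by the values given here, the only measured step, a number 0.2 percentage points lower from compound 1 to compound 2 (within the scatter), is within the scatter, so compound 1 stands at the top of the two numbers in name only; both compounds show almost complete inhibition of growth at the concentration tested.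

Compound 3 `CN(C)C(=O)c1cc2cnc(Nc3ccc(NC(=O)C4(C(=O)Nc5cccc(F)c5)CC4)cc3)nc2n1C1CCCC1` carries the same change at another place on the ring: fluoro in place of hydrogen on an aromatic carbon. Among the compounds with values here, the one measured step that bears on it, the fluorine substitution read as a number 0.2 percentage points lower from compound 1 to compound 2 (within the scatter), did nothing beyond the scatter, and there is no other example of a substituent on this ring in the data. The account therefore expects no step beyond the scatter in this assay, with the estimated change being a number 0.8 percentage points lower from compound 1 to compound 3 (within the scatter). Compound 3 is estimated at 88%, with a range from 78% to 95%.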

Compound 3, percent growth inhibition at one concentration: 91.8%
Beside the measured number, compound 3's estimate is 3.8 percentage points below it; the range from low to high includes it.
By their numbers in this assay, from the lowest: compounds 2, 1 and 3 (each within the scatter of the next).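

In this assay, fluoro at this second place on the ring, as the 3-fluorophenyl group, gives a number 3 percentage points higher from compound 1 to compound 3 (within the scatter) and so, like the 2-fluorophenyl change before it, leaves the reading inside the scatter. Going by these compounds alone, the new compound also allows the first direct comparison between two fluorine placings: 3-fluorophenyl in place of 2-fluorophenyl on an amide-type nitrogen gives a number 3.2 percentage points higher from compound 2 to compound 3 (within the scatter) and does not separate the two fluorinated compounds, so across these three compounds neither adding fluoro at either place nor shifting it between them registers as a real difference at this single concentration. No evidence is at hand that would explain this result.

The compounds shown carry only hydrogen or fluoro on this ring, so it remains open whether a different group there, such as methoxy, trifluoromethyl or an amine, would move the reading beyond the scatter. Also open, on these data alone, is whether compound 1, compound 2 and compound 3 would separate at a lower concentration or in a full dose-response measurement, given that each is represented here by a single reading of almost complete growth inhibition.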